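The compounds below may be only part of what the source reports. "The series", "measured", "known", "first", "only" and "open" are said of these compounds alone.

In a functional assay on HepG2 cells (Homo sapiens) for antiproliferative activity, read by sulforhodamine B assay, with a stated time of 3 days (a lower number here means that less compound is needed, a higher number that more compound is needed for the effect), compound 1 (`CCCC1=C(OC)C(CCC)(CCC)C(=O)/C(=C(O)\C=C\c2ccccc2)C1=O`) has the entry "not determined" (no result reported), so it gives the series no number to start from. Two relatives do carry results. Compound 2 (`CCCC1=C(OC)C(CCC)(CCC)C(=O)/C(=C(O)\C=C\c2ccc(I)cc2)C1=O`) gives 2.4 uM, and compound 3 (`CCCC1(CC=C(C)C)C(=O)C(C(=O)/C=C/c2ccccc2)=C(O)C(CCC)(CCC)C1=O`) gives 6.4 uM. Among the compounds with values here, neither of them is a single-change neighbour of compound 1, so no measured step is available for comparison.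

The compound still to be tested is compound 4 (`CCCOC1=C(CCC)C(=O)/C(=C(O)/C=C/c2ccccc2)C(=O)C1(CCC)CCC`). Its difference from compound 1 is ethyl in place of hydrogen on a saturated chain carbon bound to an oxygen on an unsaturated carbon, which also reads as methoxy to propoxy. Compound 1 has no number, so any step to compound 4 could not be read directly in this assay. Even so, the expected step is none beyond the scatter, with no favoured direction. The expectation therefore leans on compound 2 at 2.4 uM and compound 3 at 6.4 uM. For compound 4 the estimated value is 5 uM, with an expected range from 1.5 uM to 16 uM.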

Compound 4, concentration for half-maximal effect: 8.3 uM
For compound 4 the middle estimate is 1.7-fold (0.22 log units) below the measured one; the measured number falls inside the stated range.
By their numbers in this assay, from the lowest: compound 2; then compounds 3 and 4 (each within the scatter of the next).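

Compound 4 yields no readable step: compound 1, its single-change relative, has no number to compare it with. The compounds shown leave open whether methoxy to propoxy shifts the result at all. No supporting evidence bears on this result.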